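A few compounds are considered here, and "the series" means these few. Any claim that something is new, unique, unknown or untested is made for them only; others in the source may bear on it.

Compound 1, `CN(C(=O)NC(=O)c1ccc(Cl)cc1Cl)c1nc(C(F)(F)F)c(C(=O)N/N=C/c2ccc(C(F)(F)F)cc2)s1`, was tested in a functional assay on A549 cells (Homo sapiens) for inhibition, read by MTT assay, with a stated time of 72 h (on this read-out lower numbers stand for stronger inhibition and higher numbers for weaker inhibition), where compound 1 gives 9.4 ug/mL. Compound 2, `CN(C(=O)NC(=O)c1ccc(F)c(F)c1)c1nc(C(F)(F)F)c(C(=O)N/N=C/c2ccc(C(F)(F)F)cc2)s1`, gives in this assay a value of 6.07 ug/mL, and the two sit close together: a 1.5-fold lower number from compound 1 to compound 2 (0.19 log units; within the scatter). Compound 3, `CN(C(=O)NC(=O)c1ccc(C(F)(F)F)cc1)c1nc(C(F)(F)F)c(C(=O)N/N=C/c2ccc(C(F)(F)F)cc2)s1`, reaches only a limit of the assay, recorded for compound 3 as > 100 ug/mL. The steps to it are large, an at least 10-fold higher number from compound 1 to compound 3 (1.02 log units; beyond the scatter) and an at least 16-fold higher number from compound 2 to compound 3 (1.21 log units; beyond the scatter), and both exchange the group on a carbonyl carbon.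

Compound 4, `CN(C(=O)NC(=O)c1ccc(Cl)cc1Cl)c1nc(C(F)(F)F)c(C(=O)N/N=C/c2ccccc2C(F)(F)F)s1`, has not yet been measured. It differs from compound 1 at another place entirely: 2-(trifluoromethyl)phenyl in place of 4-(trifluoromethyl)phenyl on a carbon with a double bond to nitrogen. Within the data shown here, none of the measured steps alters this carbon with a double bond to nitrogen, so they offer no direct guide to the size or the direction of the step. The expected step is therefore a 1.1-fold higher number from compound 1 to compound 4 (0.03 log units; within the scatter), a change within the scatter. The estimate for compound 4 in this assay is 10 ug/mL, lying between 3 ug/mL and 35 ug/mL.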

Compound 4, half-maximal inhibitory concentration: 15.3 ug/mL
For compound 4 the middle estimate is 1.5-fold (0.18 log units) below the measured one; measured number inside the range.
By their numbers in this assay, from the lowest: compounds 2, 1 and 4 (each within the scatter of the next, the first and the last beyond it). At a limit, above all of these: compound 3.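

Among these compounds, this is the first change at this place: in this assay, 2-(trifluoromethyl)phenyl in place of 4-(trifluoromethyl)phenyl on a carbon with a double bond to nitrogen gives a 1.6-fold higher number from compound 1 to compound 4 (0.21 log units; within the scatter), so in this one pair the same atoms, joined differently, leave the value within the usual scatter. The earlier compounds shown here showed only exchanges on a carbonyl carbon, where one step was large, an at least 10-fold higher number from compound 1 to compound 3 (1.02 log units; beyond the scatter), and they said nothing about this other end of the molecule. Nothing measured here bears on why this exchange gives so small a step.

As far as these compounds go, whether an amine or a carboxylic acid in place of trifluoromethyl on this phenyl ring would stay as close to compound 1 remains open. So does whether the same exchange would give as small a step with the 3,4-difluorophenyl group of compound 2 on the carbonyl carbon.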